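Series notes: aryl changes on the urea nitrogen

The source may hold more compounds than are shown below. What is called first, only, known or untested is meant among the compounds shown, and "the series" means these compounds.

Measured compounds:
compound 1 `Cc1cc(C)cc(NC(=O)Nc2cc(C(C)(C)C)nn2-c2ccccc2)c1` gives -0.3 degrees C
compound 2 `CC(C)(C)c1cc(NC(=O)Nc2ccc(F)c(F)c2)n(-c2ccccc2)n1` gives 3.4 degrees C
compound 3 `CC(C)(C)c1cc(NC(=O)Nc2ccccc2)n(-c2ccccc2)n1` gives 7.2 degrees C

The read-out throughout is an assay on isolated protein for inhibition of serine/threonine-protein kinase 10 (Homo sapiens), read by thermal shift assay, tested at 10 uM; a lower number here means that the compound stabilises the target less, a higher number that the compound stabilises the target more against heat. Compound 3 stands highest of the three, with compound 2 nearest and compound 1 furthest. The two steps into compound 3 point the same way: a number 3.8 degrees C higher from compound 2 to compound 3 (beyond the scatter) and a number 7.5 degrees C higher from compound 1 to compound 3 (beyond the scatter); also a number 3.7 degrees C higher from compound 1 to compound 2 (beyond the scatter).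

Compound 4 `Cc1ccc(NC(=O)Nc2cc(C(C)(C)C)nn2-c2ccccc2)cc1` is the next compound; the change is methyl in place of hydrogen on an aromatic carbon. Both measured substitutions on this ring lowered this assay relative to compound 3, so for compound 4 a drop is expected, probably a modest one, of about a number 2.7 degrees C lower from compound 3 to compound 4 (beyond the scatter). Compound 4 is accordingly estimated at 4.5 degrees C, within 2 degrees C to 7 degrees C.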

Compound 4, shift of the target's melting temperature: 4.7 degrees C
Estimate against measurement, compound 4: 0.20 degrees C below; measured number inside the range.
By their numbers in this assay, from the lowest: compound 1; then compound 2; then compound 4; then compound 3.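

A single methyl on the aromatic carbon para to a large group is already enough to move the number, a number 2.5 degrees C lower from compound 3 to compound 4 (beyond the scatter), so among these four compounds none of the substituted rings reaches the unsubstituted phenyl of compound 3. The 4-methylphenyl ring still stands above both other substituted rings, with a number 1.3 degrees C higher from compound 2 to compound 4 (beyond the scatter) and a number 5.0 degrees C higher from compound 1 to compound 4 (beyond the scatter). Nothing at hand accounts for these steps.

Open, on these data alone, is whether a methoxy group or an amine at this same place would fall like methyl or stay near phenyl. Also open, as far as these compounds go, is how a longer chain, such as ethyl, would read here.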